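Quinoxaline sulfone series: anilines, cytotoxicity, one open compound

A few compounds are considered here, and "the series" means these few. Any claim that something is new, unique, unknown or untested is made for them only; others in the source may bear on it.

Measured so far:
compound 1 `COc1cc(Nc2nc3ccccc3nc2S(=O)(=O)c2ccc(C)cc2)cc(OC)c1`: 8060 nM
compound 2 `Cc1ccc(S(=O)(=O)c2nc3ccccc3nc2Nc2ccc(N)cc2)cc1`: 24600 nM
compound 3 `COc1cc(Nc2nc3ccccc3nc2S(=O)(=O)c2ccc(F)cc2)cc(OC)c1`: 5450 nM

In a functional assay on A549 cells (Homo sapiens) for cytotoxicity, read by MTT assay, with a stated time of 72 h (a higher number here means a weaker inhibitor, a lower number a stronger inhibitor), compound 1 gives 8060 nM. Compound 2 `Cc1ccc(S(=O)(=O)c2nc3ccccc3nc2Nc2ccc(N)cc2)cc1` carries the change (4-aminophenyl in place of 3,5-dimethoxyphenyl on a nitrogen on an aromatic ring), and in this assay compound 2 gives 24600 nM; the step is a 3.1-fold higher number from compound 1 to compound 2 (0.48 log units; beyond the scatter). Compound 3 `COc1cc(Nc2nc3ccccc3nc2S(=O)(=O)c2ccc(F)cc2)cc(OC)c1` differs from compound 1 by fluoro in place of methyl on an aromatic carbon, and in this assay compound 3 gives 5450 nM; the step is a 1.5-fold lower number from compound 1 to compound 3 (0.17 log units; within the scatter), so compounds 1 and 3 cannot be ordered against each other.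

Compound 4 `Nc1ccc(Nc2nc3ccccc3nc2S(=O)(=O)c2ccc(F)cc2)cc1` has not yet been measured. It differs from compound 3 by 4-aminophenyl in place of 3,5-dimethoxyphenyl on a nitrogen on an aromatic ring, which is the same change as that from compound 1 to compound 2, and the place around it is the same word for word. The two cores differ by the change (fluoro in place of methyl on an aromatic carbon), which made a step within the scatter.

Going by the values given here, only one measured instance of this change exists, so the expectation rests on a single pair. Among the compounds with values here, the step from compound 3 to compound 4 in this assay is expected to be a 3.1-fold higher number from compound 3 to compound 4 (0.49 log units; beyond the scatter) because a 3.1-fold higher number from compound 1 to compound 2 (0.48 log units; beyond the scatter) is the only measured step for this change. On that basis compound 4 is estimated at 17000 nM in this assay, with an expected range from 8000 nM to 40000 nM.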

Compound 4, half-maximal inhibitory concentration: 12700 nM
Estimate against measurement, compound 4: 1.3-fold (0.13 log units) above, and the stated range covers the measured number.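

In this assay, 4-aminophenyl in place of 3,5-dimethoxyphenyl on a nitrogen on an aromatic ring again gives a step beyond the scatter on the fluoro-bearing core, a 2.3-fold higher number from compound 3 to compound 4 (0.37 log units; beyond the scatter), and this step does not differ from the one on the methyl-bearing core: the same change on two cores in this assay, a 3.1-fold higher number (0.48 log units; beyond the scatter) from compound 1 to compound 2 and a 2.3-fold higher number (0.37 log units; beyond the scatter) from compound 3 to compound 4, 1.3-fold (0.12 log units) apart, within the scatter of two such steps

The other exchange in the set, fluoro in place of methyl on an aromatic carbon, now read with 4-aminophenyl on the nitrogen, gives a 1.9-fold lower number from compound 2 to compound 4 (0.29 log units; within the scatter), which is within the scatter, as the earlier step with 3,5-dimethoxyphenyl also is, so this exchange shows no measurable effect on either background: the same change on two cores in this assay, a 1.5-fold lower number (0.17 log units; within the scatter) from compound 1 to compound 3 and a 1.9-fold lower number (0.29 log units; within the scatter) from compound 2 to compound 4, 1.3-fold (0.12 log units) apart, within the scatter of two such steps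

Going by these compounds alone, this supports carrying the aniline change between these closely related cores, but it rests on only two pairs in a single cell assay, and it shows neither how the change would behave on a more distant core nor why the numbers move.

The compounds shown leave open whether the step belongs to the loss of the methoxy groups, the arrival of the amine, or both, since the two groups change together in each pair. They also leave open what a chloro or a trifluoromethyl group would do in place of fluoro, or a single methoxy group or a dimethylamino group on the aniline ring.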